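The compounds below may be only part of what the source reports. "The series", "measured", "known", "first", "only" and "open" are said of these compounds alone.

Notes on the series, all read in a functional assay on KB-V1 cells (Homo sapiens) for cytotoxicity, read by MTT assay, with a stated time of 72 h; a higher number here means a weaker inhibitor, a lower number a stronger inhibitor. Compound 1 `O=C1Nc2ccccc2/C1=N/NC(=S)Nc1cccc(Cl)c1` gives 640 nM, compound 2 `O=C1Nc2ccccc2/C1=N/NC(=S)Nc1ccc(Cl)cc1` gives 4990 nM, and compound 3 `O=C1Nc2ccccc2/C1=N/NC(=S)Nc1ccc(Oc2ccccc2)cc1` gives 1670 nM, the middle of the three numbers. Compound 4 `CCCC1CCC(c2ccc(NC(=S)N/N=C3\C(=O)Nc4ccccc43)cc2)CC1` carries 4-propylcyclohexyl in place of phenoxy on an aromatic carbon. The nearest evidence is a 3.0-fold lower number from compound 2 to compound 3 (0.48 log units; beyond the scatter), a modest step at the same carbon. The other step, a 7.8-fold higher number from compound 1 to compound 2 (0.89 log units; beyond the scatter), is also modest but only moves the chloro group. Neither step tests a non-aromatic ring, so in this assay no step beyond the scatter is expected, with a slight lean towards a lower number. The estimated step is a 1.3-fold lower number from compound 3 to compound 4 (0.11 log units; within the scatter). For compound 4 the expected value is 1300 nM, with an estimated range of 400 nM to 4000 nM.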

Compound 4, half-maximal inhibitory concentration: 11000 nM
Compound 4: the middle estimate sits 8.5-fold (0.93 log units) below what was measured, and the stated range ends below it.
By their numbers in this assay, from the lowest: compound 1; then compound 3; then compound 2; then compound 4.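

In this assay the change of phenoxy to 4-propylcyclohexyl gives a 6.6-fold higher number from compound 3 to compound 4 (0.82 log units; beyond the scatter) and shows that, at this carbon, an all-carbon non-aromatic ring does not stand in for the aromatic ring of phenoxy. Set against chloro, the same group gives a 2.2-fold higher number from compound 2 to compound 4 (0.34 log units; beyond the scatter) so the larger group does not simply lower the number: phenoxy lies below chloro, 4-propylcyclohexyl above it. Nothing available explains this shift.

Still open, as far as these compounds go, is whether the propyl chain or the non-aromatic ring carries the change. Plain cyclohexyl at this carbon would separate the two, and a morpholine would add ring heteroatoms to the comparison.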